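This account rests on a few compounds, and the source may have more. Where it says the series, first, only, none or still open, it means among the compounds named here.

Working notes on the series. For the measured compounds named here, the shared core carries, on an aromatic nitrogen of a five-membered aromatic ring with 3 nitrogen, a substituted phenyl, and that phenyl is the only place where the compounds differ. Compound 1 `Cc1ccccc1-n1nncc1CN1C(=O)C2(C(C#N)=C(N)Oc3c2c2nc4ccccc4nc2c2ccccc32)c2ccccc21` bears 2-methylphenyl there. In a functional assay on HCT-116 cells (Homo sapiens) for antiproliferative activity, read by MTT assay, with a stated time of 48 h (on this read-out lower numbers stand for stronger inhibition and higher numbers for weaker inhibition), compound 1 gives > 50000 nM, which is a limit of the assay and not a number. Compound 2 `N#CC1=C(N)Oc2c(c3nc4ccccc4nc3c3ccccc23)C12C(=O)N(Cc1cnnn1-c1ccc(Br)cc1)c1ccccc12` bears 4-bromophenyl. In this assay compound 2 gives > 50000 nM, again only a limit. Compound 3 `Cc1ccc(-n2nncc2CN2C(=O)C3(C(C#N)=C(N)Oc4c3c3nc5ccccc5nc3c3ccccc43)c3ccccc32)c(C)c1` bears 2,4-dimethylphenyl. In this assay compound 3 gives > 50000 nM, also a limit. Compound 3 therefore stands where every value of the series stands: the limit of > 50000 nM in this assay, at which 3 of the 3 values shown sit. The steps between the measured compounds are accordingly all unreadable: a step that the two limits leave unreadable from compound 1 to compound 2, a step that the two limits leave unreadable from compound 1 to compound 3 and a step that the two limits leave unreadable from compound 2 to compound 3. Compound 4 `Cc1ccc(-n2nncc2CN2C(=O)C3(C(C#N)=C(N)Oc4c3c3nc5ccccc5nc3c3ccccc43)c3ccccc32)cc1Cl` differs from compound 3 by 3-chloro-4-methylphenyl in place of 2,4-dimethylphenyl on an aromatic nitrogen. Every measured step bears on this change, since each exchanges substituents on the same phenyl, yet none of them yields a size, so no direction can be read from them. The expectation for compound 4 in this assay is a step of a number no higher from compound 3 to compound 4 (the limit leaves the size open), within scatter, with the assay again most likely reporting only its limit. The value of compound 4 is estimated at 50000 nM, between 20000 nM and 120000 nM.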

Compound 4, half-maximal inhibitory concentration: > 50000 nM
Compound 4 was reported as a limit (the forecaster's own chance of this, stated with the estimate: 85%); the middle value sits exactly at the limit.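

In this assay compound 4 gives > 50000 nM, which is a limit and not a number. Its steps from compound 1, compound 2 and compound 3 therefore cannot be read, and the series stays where it stood: the limit of > 50000 nM in this assay, at which 4 of the 4 values shown sit. The compounds shown leave open whether any phenyl substituent on the shared core gives a measurable value in this assay.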